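Series notes: aryl swap on the shared core

The compounds below may be only part of what the source reports. "The series", "measured", "known", "first", "only" and "open" are said of these compounds alone.

Of the compounds shown here, three of the shared core have numbers so far. Compound 1 `O=C1O[C@]2(CC[C@H](CNc3ccc(-c4cc(F)cc(F)c4)nn3)CC2)CN1c1cccnn1` gives 0.1 nM in a functional assay for antagonist activity at Neuropeptide Y receptor type 5 (Homo sapiens); on this read-out lower numbers stand for stronger inhibition and higher numbers for weaker inhibition. Compound 2 `O=C1O[C@]2(CC[C@H](CNc3ccc(-c4ncccn4)cn3)CC2)CN1c1ccccn1` gives 0.159 nM in this assay, a value within the scatter of that of compound 1, so the two cannot be told apart. Compound 3 `O=C1O[C@]2(CC[C@H](CNc3cnn(-c4ccccc4F)c3)CC2)CN1c1cncnc1` gives 0.0398 nM in this assay, the lowest of the three numbers and beyond the scatter from compound 1. Compound 1 thus stands second highest of the three numbers, close to compound 2 and separated from compound 3.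

Compound 4 `Cc1ccccc1-c1ccc(NC[C@H]2CC[C@]3(CC2)CN(c2cccnn2)C(=O)O3)nn1` has not been measured. It differs from compound 1 in one place: 2-methylphenyl in place of 3,5-difluorophenyl on an aromatic carbon. For the measured compounds named here, no pair of measured compounds shows a change of this kind, so the size of the step is unknown from the data at hand. The three measured compounds carry different aryl groups on the same part of the core and all sit in a narrow band, which argues for a modest step. The expectation is a step from compound 1 to compound 4 of a 2.0-fold higher number from compound 1 to compound 4 (0.30 log units; within the scatter), toward a somewhat higher number, most likely within the scatter or just beyond it. For compound 4 the estimate in this assay is 0.2 nM, with a range from 0.05 nM to 0.8 nM.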

Compound 4, inhibition constant: 0.0631 nM
Beside the measured number, compound 4's estimate is 3.2-fold (0.50 log units) above it; the range from low to high includes it.
By their numbers in this assay, from the lowest: compounds 3, 4, 1 and 2 (each within the scatter of the next, the first and the last beyond it).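

For the compounds shown here, the step from 3,5-difluorophenyl to 2-methylphenyl is the first change at this position that can be read between two compounds differing in one place, and in this assay it amounts to a 1.6-fold lower number from compound 1 to compound 4 (0.20 log units; within the scatter), so the two compounds cannot be told apart. Going by these compounds alone, the position, on an aromatic carbon next to the ring nitrogen and para to a large group, thus accepts this exchange of substituents on the phenyl ring without a readable change in the number, which the earlier compounds, differing in more than one place, could not show. No evidence on the cause of this result is at hand.

Within the data shown here, the single step changes both substituent types at once, so the loss of the two fluorines and the entry of the methyl cannot be separated, and a phenyl carrying only one of these changes would be needed to read each on its own. Both groups are also uncharged and have no hydrogen-bond donors or acceptors, which leaves open how this position responds to an aminomethyl group, a carboxylic acid or a longer alkyl chain on the phenyl ring.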